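Methoxy for Hydroxymethyl Across a Series at the Limit

The source may hold more compounds than are shown below. What is called first, only, known or untested is meant among the compounds shown, and "the series" means these compounds.

Compound 1 `Nc1nc(-c2cccc(CO)c2)nc2sc(-c3ccccc3)nc12` is the starting point. In a functional assay on CHO cells for antagonist activity at adenosine receptor A2b (Homo sapiens), read by cAMP accumulation, with a stated time of 10 min (a lower number here means a stronger inhibitor, a higher number a weaker inhibitor), compound 1 gives > 30000 nM, which is a limit of the assay and not a number. Compound 2 `COc1cccc(-c2nc(N)c3nc(-c4ccccc4)sc3n2)c1` differs from compound 1 by methoxy in place of hydroxymethyl on an aromatic carbon. In this assay compound 2 gives > 30000 nM, again a limit. The step that the two limits leave unreadable from compound 1 to compound 2 cannot be sized. Compound 3 `Nc1nc(-c2ccc(CO)cc2)nc2sc(-c3ccco3)nc12` has a different core; the difference between the two cores is not broken down here. In this assay compound 3 gives > 30000 nM, also a limit. The three values all sit at the limit of > 30000 nM in this assay, at which 3 of the 3 values shown sit.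

Compound 4 `COc1ccc(-c2nc(N)c3nc(-c4ccco4)sc3n2)cc1` has not been measured. It differs from compound 3 by methoxy in place of hydroxymethyl on an aromatic carbon. This is the same kind of change as that from compound 1 to compound 2, but the group now sits para to a large group rather than meta to a large group. Because the limit of > 30000 nM in this assay, at which 3 of the 3 values shown sit, holds for every measured compound, the expectation for compound 4 rests on nothing more than that. In this assay the expected step is a step that the limit leaves unreadable from compound 3 to compound 4. Compound 4 is estimated at 40000 nM, with an expected range from 10000 nM to 150000 nM, and most probably the assay will again report only a limit.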

Compound 4, half-maximal inhibitory concentration: > 30000 nM
Compound 4 gave a limit, no number; the forecaster's own chance of this, stated with the estimate: 80%; the middle value lies beyond the limit too.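

In this assay compound 4 gives > 30000 nM, a limit of the assay and not a number. No step can be read from compound 3 to compound 4, and the series offers no number to compare: the limit of > 30000 nM in this assay, at which 4 of the 4 values shown sit. The compounds shown leave open what size or direction, if any, the change from hydroxymethyl to methoxy has in this assay.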